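The compounds below may be only part of what the source reports. "The series", "measured", "known", "first", "only" and "open" are said of these compounds alone.

Working notes on the series.

Three compounds sharing one core have numbers in a functional assay on HeLa cells (Homo sapiens) for antiproliferative activity, read by sulforhodamine B assay, with a stated time of 72 h; a lower number here means a stronger inhibitor, a higher number a weaker inhibitor. Compound 1 `O=C1CS/C(=N/Nc2nncc3ccccc23)N1c1ccccc1` gives 56 nM. Compound 2 `Cc1cc(NS(=O)(=O)c2ccc(Nc3nncc4ccccc34)cc2)no1` gives 13 nM. Compound 3 `C(=C/c1ccccc1)\C(=N\Nc1nncc2ccccc12)c1ccccc1` gives 1.4 nM. Compound 2 thus stands second highest of the three numbers: compound 1 sits nearest with a higher number, compound 3 furthest with a lower number, and both of those gaps lie beyond the scatter of this assay. Within the data shown here, no pair of the measured compounds differs in only one place, so no single-point step has been read directly.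

Compound 4 `NS(=O)(=O)c1ccc(Nc2nncc3ccccc23)cc1` is not yet measured in this assay. It differs from compound 2 in one place: hydrogen in place of 5-methyl-1,2-oxazol-3-yl on a sulfonamide nitrogen. Among the measured compounds shown here, no measured pair shows what such a change does in this assay, so the expectation leans on compound 2 alone. For compound 4 the expected step of a 3.1-fold higher number from compound 2 to compound 4 (0.49 log units; beyond the scatter) is a modest move toward a higher number, likely just beyond the scatter rather than a large shift. Compound 4 is therefore estimated at 40 nM in this assay, with a range of 10 nM to 160 nM.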

Compound 4, half-maximal inhibitory concentration: 12 nM
Compound 4: the middle estimate sits 3.3-fold (0.52 log units) above what was measured, within the range that was stated.
By their numbers in this assay, from the lowest: compound 3; then compounds 4 and 2 (each within the scatter of the next); then compound 1.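

Among these compounds, the first single-point step, read in this assay, is a 1.1-fold lower number from compound 2 to compound 4 (0.03 log units; within the scatter): hydrogen in place of 5-methyl-1,2-oxazol-3-yl on a sulfonamide nitrogen leaves the number within the scatter. At this position, then, the whole five-membered aromatic ring can be lost with no readable change in this read-out, so the ring is not needed to hold the number at the level of compound 2. Nothing at hand accounts for this outcome.

As far as these compounds go, whether other groups on this sulfonamide nitrogen, such as a methyl, an acetyl or a phenyl group, would also leave the number in place remains open. A single pair also cannot tell whether the same change would read alike on a compound with a different link to the shared core.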